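Pyrazole ureas: a second trifluoromethyl on the aryl urea

The source may report more compounds than this note shows. Statements on the series, on what has been measured and on what is new or still open speak of the compounds shown alone.

Compound 1 `O=C(Nc1cccc(-n2cc(-c3ccncc3)c(-c3ccc(Cl)c(O)c3)n2)c1)Nc1cccc(C(F)(F)F)c1` is measured in a functional assay on Malme-3M cells (Homo sapiens) for inhibition, read by sulforhodamine B assay, with a stated time of 48 h (a higher number here means a weaker inhibitor of growth, a lower number a stronger inhibitor of growth), and gives 20100 nM. Of the three numbers in hand this is the highest. Compound 3 `COc1cc(-c2nn(-c3cccc(NC(=O)c4ccc(Cl)c(C(F)(F)F)c4)c3)cc2-c2ccncc2)ccc1Cl` carries an amide and a methoxy group where compound 1 has a urea and a hydroxyl; in this assay compound 3 gives 19700 nM, and the two numbers sit within the scatter of each other. For the measured compounds named here, compound 2 `O=C(Nc1cccc(-n2cc(-c3ccncc3)c(-c3ccc(Cl)c(O)c3)n2)c1)Nc1ccc(Cl)c(Cl)c1` gives 8100 nM, and the step of a 2.5-fold lower number from compound 1 to compound 2 (0.39 log units; beyond the scatter) is the only single-point change recorded so far; it is modest, and it concerns the same aryl ring on the urea nitrogen that is altered below.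

Compound 4 `O=C(Nc1cccc(-n2cc(-c3ccncc3)c(-c3ccc(Cl)c(O)c3)n2)c1)Nc1cc(C(F)(F)F)cc(C(F)(F)F)c1` differs from compound 1 by trifluoromethyl in place of hydrogen on an aromatic carbon. Going by the values given here, no measured pair shows exactly this change. Among the compounds with values here, the one step that bears on it, a 2.5-fold lower number from compound 1 to compound 2 (0.39 log units; beyond the scatter), changed the substituents of the same ring and moved the number by a modest amount; a second trifluoromethyl on that ring is a change of similar scope, so a step of at most that size is expected, in either direction, or none beyond the scatter.

For compound 4 the expected value in this assay is 15000 nM, with a range from 6000 nM to 40000 nM, a step of a 1.3-fold lower number from compound 1 to compound 4 (0.13 log units; within the scatter) that is estimated to stay close to the scatter.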

Compound 4, concentration for total growth inhibition: 3030 nM
Compound 4: the middle estimate sits 5.0-fold (0.69 log units) above what was measured; measured number below the stated range.
By their numbers in this assay, from the lowest: compound 4; then compound 2; then compounds 3 and 1 (each within the scatter of the next).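

In this assay, the step of a 6.6-fold lower number from compound 1 to compound 4 (0.82 log units; beyond the scatter) shows that this aromatic carbon, meta to a trifluoromethyl group, responds to a second trifluoromethyl, with the rest of compound 1 unchanged. Compound 1 now has two listed neighbours that differ from it only on the aryl ring of the urea, and both changes lower the number: the earlier step of a 2.5-fold lower number from compound 1 to compound 2 (0.39 log units; beyond the scatter) and the step to compound 4, so among these three compounds the lone trifluoromethyl of compound 1 gives the highest number. Nothing available explains why adding this group lowers the number.

Going by these compounds, it remains open whether the step belongs to trifluoromethyl itself or would also appear with another group on the same aromatic carbon, such as a nitrile, a methyl or a carboxylic acid. On these data alone, it is equally open whether the same change would lower the number on the amide and methoxy compound 3, which differs from compound 1 in more than one place and so gives no direct reading of this position.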